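The source may report more compounds than this note shows. Statements on the series, on what has been measured and on what is new or still open speak of the compounds shown alone.

Compound 1, with the structure `C/N=C(\S)CCn1nc(-c2ccccc2)ccc1=O`, was tested in a functional assay on the whole organism (stomach) for inhibition, with Rattus norvegicus as the target, at a dose of 100 mg/kg by the intraduodenal route (on this read-out lower numbers stand for less inhibition and higher numbers for more inhibition at the one dose given (going by the name of the read-out)), where compound 1 gives 68.2%. Its companion, compound 2, with the structure `N=C(S)CCn1nc(-c2cccs2)ccc1=O`, gives 50.2% in this assay. Of the two numbers shown, compound 1 is the higher one, and the gap to compound 2 lies beyond the usual scatter of repeated measurements.

The next compound, compound 3, has the structure `CC(CC(=N)S)n1nc(-c2ccccc2)ccc1=O`. It differs from compound 1 only in the side chain on the aromatic nitrogen: a group of 6 heavy atoms (4 carbon, 1 nitrogen, 1 sulfur; no ring) in place of a group of 6 heavy atoms (4 carbon, 1 nitrogen, 1 sulfur; no ring), on an aromatic nitrogen. The atoms are the same; they are joined differently, and the count of hydrogen-bond donors in the chain rises by one.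

Among the measured compounds shown here, no measured pair shows a change of this exact kind, so the expectation for compound 3 rests on the two values above. A step in this assay from compound 1 to compound 3 of a number 10.2 percentage points lower from compound 1 to compound 3 (beyond the scatter) is expected, a modest fall that may not exceed the scatter, partly because compound 2 with its own free thioamide-type chain gives 50.2%. Compound 3 is therefore expected to show 58% in this assay, within a range from 35% to 80%.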

Compound 3, a percentage reported as inhibition, in the whole organism at one dose (the size of the read-out at that dose, not a potency): 15.5%
The estimate for compound 3 lay 42.5 percentage points above the measured number; the whole stated range lies above it.
By their numbers in this assay, from the lowest: compound 3; then compound 2; then compound 1.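

In this assay, the side chain on the aromatic nitrogen proves sensitive to how its atoms are joined: the same 6 heavy atoms, arranged differently, give a number 52.7 percentage points lower from compound 1 to compound 3 (beyond the scatter) on an otherwise unchanged core. What the chain contains therefore does not settle the result at this position, and the arrangement of those atoms matters as well, a point that compound 1 and compound 2 could not show, as they differ in more than one place. The chains that leave and enter share their heavy atoms, their lack of a ring and their 1 double bond, and differ in counting 1 and 2 hydrogen-bond donors, but nothing measured here explains the size of the step.

The two compounds do not separate the effect of the rearranged carbon skeleton from that of the changed donor count, as both changes arrive together in a single step. Going by these compounds, how a longer chain, or a carboxylic acid at the end of the chain, would behave in this assay also remains open.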